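Swapping Methyl for Fluoro on a Cytotoxic Dienone

The compounds below may be only part of what the source reports. "The series", "measured", "known", "first", "only" and "open" are said of these compounds alone.

Of the compounds shown here, two sharing one core have been measured in a functional assay on L1210 cells (Mus musculus) for cytotoxicity, with a stated time of 48 h; a higher number here means a weaker inhibitor, a lower number a stronger inhibitor. Compound 1 `O=C1/C(=C/c2ccccc2)CCC/C1=C\c1cccc([N+](=O)[O-])c1` carries an unsubstituted phenyl ring and gives 9440 nM. Compound 2 `Cc1ccc(/C=C2\CCC/C(=C\c3cccc([N+](=O)[O-])c3)C2=O)cc1` has a methyl group added to that ring, and in this assay compound 2 gives 41800 nM, the higher of the two numbers; the step of a 4.4-fold higher number from compound 1 to compound 2 (0.65 log units; beyond the scatter) shows that adding the methyl weakened the compound by a modest but real amount.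

Compound 3 `O=C1/C(=C/c2ccc(F)cc2)CCC/C1=C\c1cccc([N+](=O)[O-])c1` is the next step: fluoro in place of methyl on an aromatic carbon. Going by the values given here, the only measured step that bears on this change is the one from compound 1 to compound 2, which concerns the methyl alone; nothing measured here tells what fluoro does at this place. Removing the methyl would, on that single step, be expected to bring the number back toward that of compound 1, while the entering fluoro is an unknown. The step of a 2.8-fold lower number from compound 2 to compound 3 (0.45 log units; beyond the scatter) is therefore expected to be a moderate decrease. Compound 3 is estimated at 15000 nM, with a range from 5000 nM to 45000 nM.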

Compound 3, half-maximal inhibitory concentration: 16300 nM
The estimate for compound 3 lay 1.1-fold (0.04 log units) below the measured number; low and high end bracket the measured number.
By their numbers in this assay, from the lowest: compounds 1 and 3 (each within the scatter of the next); then compound 2.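

In this assay, the ring carbon that held the methyl of compound 2 can also carry a substituent with no clear loss: the step of a 1.7-fold higher number from compound 1 to compound 3 (0.24 log units; within the scatter) stays inside the usual scatter, so fluoro at this place cannot be told apart from plain hydrogen. The exchange of the two groups is a real one, with the step of a 2.6-fold lower number from compound 2 to compound 3 (0.41 log units; beyond the scatter) lying beyond the scatter, which means the weakening seen with methyl does not apply to every group placed on this carbon. No measurement available here explains why these two single-atom groups behave differently.

With only hydrogen, methyl and fluoro shown at this place, there is no telling whether a longer chain such as ethyl would weaken the compound further than methyl does, or whether a larger halogen such as chlorine would stay as close to compound 1 as fluoro does. From the compounds shown here alone, how an amine or a carboxylic acid on this carbon would fare also remains open, as does whether fluoro would give the same result elsewhere on the ring.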